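The source may hold more compounds than are shown below. What is called first, only, known or untested is meant among the compounds shown, and "the series" means these compounds.

Measured so far:
compound 1 `OC[C@H]1O[C@@H](n2cnc3c(NCc4ccc(Cl)cc4)ncnc32)[C@H](O)[C@@H]1O` — in a functional assay on B16 cells (Mus musculus) for antiproliferative activity, with a stated time of 72 h (on this read-out higher numbers stand for weaker inhibition and lower numbers for stronger inhibition), compound 1 gives > 166000 nM
compound 2 `Cc1cccc(CNc2ncnc3c2ncn3[C@@H]2O[C@H](CO)[C@@H](O)[C@H]2O)c1` — in this assay compound 2 gives > 166000 nM
compound 3 `COc1cc(CNc2ncnc3c2ncn3[C@@H]2O[C@H](CO)[C@@H](O)[C@H]2O)cc(OC)c1` — in this assay compound 3 gives "not determined" (no result reported)

The value shown for compound 2 is a limit of the assay, not a number. The value shown for compound 1 is likewise a limit. Compound 3 has no result at all. For the measured compounds named here, compound 2 therefore stands at the edge of what this assay can report, and the only step among measured compounds, a step that the two limits leave unreadable from compound 1 to compound 2, cannot be read as a size in either direction; the reason is that (the limit of > 166000 nM in this assay, at which 2 of the 3 values shown sit).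

Compound 4 `OC[C@H]1O[C@@H](n2cnc3c(NCc4ccc(F)cc4Cl)ncnc32)[C@H](O)[C@@H]1O` differs from compound 2 in one place: 2-chloro-4-fluorophenyl in place of 3-methylphenyl on a saturated chain carbon bound to a nitrogen on an aromatic ring. Going by the values given here, no measured step bears on this change, so there is no basis to expect any step beyond the scatter, nor a direction for it. Compound 4 is expected to sit near the limit again, estimated at about 166000 nM, with a range from 50000 nM to 500000 nM. The estimated step of a number no higher from compound 2 to compound 4 (the limit leaves the size open) is expected to stay within the scatter.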

Compound 4, half-maximal inhibitory concentration: > 166000 nM
Compound 4: only a limit was reported; the forecaster's own chance of this, stated with the estimate: 75%; the middle value sits exactly at the limit.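

In this assay compound 4 gives > 166000 nM, which is a limit and not a number. The steps joining compound 1, compound 2 and compound 4 cannot be read as sizes, because all three sit at the same edge: the limit of > 166000 nM in this assay, at which 3 of the 4 values shown sit. As far as these compounds go, how these three compounds rank, and whether exchanging these groups changes inhibition at all, stays open.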